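A few compounds are considered here, and "the series" means these few. Any claim that something is new, unique, unknown or untested is made for them only; others in the source may bear on it.

Measured compounds:
- Compound 1 `O=C1C(Nc2ccc(I)cc2)=CC(=O)c2c1nc1n2[C@H]2OC[C@@H](O)[C@H]2OC1`: 2150 nM
- Compound 2 `O=C1C=C(N2CCC2)C(=O)c2c1nc1n2[C@H]2OC[C@@H](O)[C@H]2OC1`: > 16000 nM
- Compound 3 `O=C1C=C(Nc2ccccc2F)C(=O)c2c1nc1n2[C@H]2OC[C@@H](O)[C@H]2OC1`: 2080 nM

In a functional assay on MGC-803 cells (Homo sapiens) for inhibition, read by sulforhodamine B assay (on this read-out higher numbers stand for weaker inhibition and lower numbers for stronger inhibition), compound 1 gives 2150 nM, the highest of the two numbers shown, and compound 3 sits within the scatter of it. For compound 2 the assay reports only a limit, > 16000 nM, not a number. Within the data shown here, the one step measured is an at least 7.6-fold lower number from compound 2 to compound 3 (0.88 log units; beyond the scatter), so exchanging a small saturated nitrogen ring for an arylamine lowered the number well beyond the scatter. Compound 4 `O=C1C(N2CCCC2)=CC(=O)c2c1nc1n2[C@H]2OC[C@@H](O)[C@H]2OC1` is the untested partner of compound 1, with pyrrolidin-1-yl in place of (4-iodophenyl)amino on a double-bonded ring carbon. This runs opposite to the measured step, so a higher number, probably again a limit, is expected: a 9.3-fold higher number from compound 1 to compound 4 (0.97 log units; beyond the scatter). Compound 4 is estimated at 20000 nM, between 6000 nM and 60000 nM.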

Compound 4, half-maximal inhibitory concentration: > 16000 nM
Compound 4: only a limit was reported (the forecaster's own chance of this, stated with the estimate: 70%); the middle value does not contradict the limit.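

In this assay, the change gives an at least 7.4-fold higher number from compound 1 to compound 4 (0.87 log units; beyond the scatter), so the pattern from the earlier step also holds for pyrrolidin-1-yl and (4-iodophenyl)amino on this double-bonded ring carbon. Across the four compounds, both arylamines give measured numbers, while both saturated nitrogen rings do not. Compound 4 gives only a limit, so the full size of this step stays unknown: the limit of > 16000 nM in this assay, at which 2 of the 4 values shown sit.

Still open, as far as these compounds go, is how an open-chain amine such as dimethylamino or a benzylamino group would read here. Either could help separate the role of the aromatic ring from that of the amine hydrogen.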